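A few compounds are considered here, and "the series" means these few. Any claim that something is new, unique, unknown or untested is made for them only; others in the source may bear on it.

Measured so far in a functional assay on CHO cells for agonist activity at Alpha-1D adrenergic receptor (Homo sapiens), read by FLIPR and calcium flux; a higher number here means a larger maximal response, a lower number a smaller maximal response:

compound 1, `Cc1n[nH]cc1-c1cccc2c1CCC2c1ncc[nH]1`, 66%
compound 2, `c1cc(-c2ccn[nH]2)c2c(c1)C(c1ncc[nH]1)CC2`, 57%
compound 3, `c1cc(-c2ncco2)c2c(c1)C(c1ncc[nH]1)CC2`, 38%

Compound 3 holds the lowest of the three values; compound 2 is the nearest, and the gap from compound 1 is the widest. Both steps in the series that end at compound 3 bear on the next change: a number 28 percentage points lower from compound 1 to compound 3 (beyond the scatter) and a number 19 percentage points lower from compound 2 to compound 3 (beyond the scatter), each a modest drop when 1,3-oxazol-2-yl enters.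

Compound 4, `c1cc(-c2nccs2)c2c(c1)C(c1ncc[nH]1)CC2`, differs from compound 3 as follows: 1,3-thiazol-2-yl in place of 1,3-oxazol-2-yl on an aromatic carbon. Going by the values given here, no measured step exchanges one of these two groups for the other, so the direction in this assay is uncertain. Given the value of compound 3, 38%, a step of a number 4 percentage points higher from compound 3 to compound 4 (within the scatter) is expected, within the scatter. Compound 4 is estimated at 42%, range 28% to 58%.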

Compound 4, largest response reached (Emax), in percent of the reference or control that the assay uses: 27%
Compound 4: middle estimate off by 15 percentage points, on the high side; the whole stated range lies above it.
By their numbers in this assay, from the lowest: compound 4; then compound 3; then compounds 2 and 1 (each within the scatter of the next).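

Exchanging 1,3-oxazol-2-yl for 1,3-thiazol-2-yl on this aromatic carbon is not a neutral change: a number 11 percentage points lower from compound 3 to compound 4 (beyond the scatter) in this assay, although the two groups match in heavy atoms, hydrogen-bond donors and acceptors. The gaps to the pyrazole-bearing compounds are wider, a number 30 percentage points lower from compound 2 to compound 4 (beyond the scatter) and a number 39 percentage points lower from compound 1 to compound 4 (beyond the scatter), which leaves compound 4 lowest of the four. Nothing available explains the difference between the two groups.

From the compounds shown here alone, whether a methyl group on the 1,3-thiazol-2-yl ring would change the response stays open. So does the response with a non-aromatic group on this carbon, such as an amine or a carboxylic acid.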